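The source may report more compounds than this note shows. Statements on the series, on what has been measured and on what is new or still open speak of the compounds shown alone.

Measured compounds:
compound 1, `C[C@@H]1CN(c2cccc(NS(=O)(=O)c3ccc(-c4ccccn4)s3)c2)C[C@H](C)N1` — 39.8 nM
compound 2, `CCOc1ccc(N2C[C@@H](C)N[C@@H](C)C2)cc1NS(=O)(=O)c1ccc(-c2ccccn2)s1` — 39.8 nM

In a functional assay for agonist activity at growth hormone secretagogue receptor type 1 (Homo sapiens), read by FLIPR (on this read-out higher numbers stand for an effect only at larger amounts of compound and lower numbers for an effect already at smaller amounts), compound 2 stands level with compound 1 at the digits shown; the step from compound 1 to compound 2 was no change at the digits printed from compound 1 to compound 2 (within the scatter), ethoxy in place of hydrogen on an aromatic carbon. Compound 3, `CC(C)Oc1ccc(N2C[C@@H](C)N[C@@H](C)C2)cc1NS(=O)(=O)c1ccc(-c2ccccn2)s1`, now follows from compound 2 by methyl in place of hydrogen on a saturated chain carbon bound to an oxygen on an aromatic ring and a saturated chain carbon. Among the compounds with values here, only one measured step exists, and it bears on this change only at one remove: it concerns the same alkoxy group but tells of putting it in place of hydrogen, not of lengthening it, and it was flat. Within the data shown here, no measured pair shows what ethyl to isopropyl on this oxygen does. Among the measured compounds shown here, with the one relevant step flat, compound 3 is expected to sit about where compound 2 sits, a step of a 1.0-fold higher number from compound 2 to compound 3 (0.00 log units; within the scatter) that lies within the scatter. As far as these compounds go, for compound 3 the estimate in this assay is therefore 40 nM, with a range from 15 nM to 110 nM, the width reflecting that the chain extension itself is untested.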

Compound 3, half-maximal effective concentration: 100 nM
Estimate against measurement, compound 3: 2.5-fold (0.40 log units) below, within the range that was stated.
By their numbers in this assay, from the lowest: compounds 1 and 2 (each within the scatter of the next); then compound 3.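

In this assay, within the data shown here, the methyl on the saturated chain carbon bound to an oxygen on an aromatic ring and a saturated chain carbon gives the first step that lies beyond the scatter, a 2.5-fold higher number from compound 2 to compound 3 (0.40 log units; beyond the scatter), though a modest one. Ethoxy to isopropoxy is therefore not a neutral exchange here, even though ethoxy in place of hydrogen gave no change at the digits printed from compound 1 to compound 2 (within the scatter). Read against the unsubstituted compound, isopropoxy in place of hydrogen gives a 2.5-fold higher number from compound 1 to compound 3 (0.40 log units; beyond the scatter), so on these three compounds the aromatic carbon carries ethoxy without a visible step, and the single further methyl is what separates the values; no measurement shown offers an explanation for this difference.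

The compounds shown leave open whether the step comes from the branched shape of isopropoxy or simply from the added carbon, a question that a straight propoxy chain would address. They also leave open how methoxy, tert-butoxy or cyclopropoxy would stand at this place, and whether the same methyl would give a similar step on another core.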